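The compounds below may be only part of what the source reports. "The series", "measured", "known", "first", "only" and "open" are said of these compounds alone.

Measured compounds:
- Compound 1 `Nc1cc(Cc2ccn(Cc3cccc(Oc4ccccc4)c3)n2)c2nn[nH]c2n1`, 44 nM in an assay on isolated protein for inhibition of Myeloperoxidase (Homo sapiens), with a stated time of 10 min; a lower number here means a stronger inhibitor, a higher number a weaker inhibitor
- Compound 2 `Nc1cc(C2CCNCCc3cccc(c3)Oc3cccc(c3)Cn3cc2cn3)c2nn[nH]c2n1`, 14 nM in this assay

Compound 1 has the higher of the two numbers in this assay; compound 2, which carries the same core built into a large ring, gives the lower value, and the gap between compound 1 and compound 2 lies beyond the usual scatter of such measurements.

Compound 3 `Nc1cc(Cc2ccn(Cc3ccccc3)n2)c2nn[nH]c2n1` has not yet been measured. It differs from compound 1 by one change: hydrogen in place of phenoxy on an aromatic carbon, meta to a large group. Nothing measured here shows this exact step, so the expectation rests on the pattern that the phenoxy-bearing compounds are the stronger ones. A moderate weakening beyond the scatter is expected, with the step of a 3.4-fold higher number from compound 1 to compound 3 (0.53 log units; beyond the scatter) estimated as the likely size. Compound 3 is therefore expected to give 150 nM in this assay, with a range of 50 nM to 500 nM.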

Compound 3, half-maximal inhibitory concentration: 120 nM
Estimate against measurement, compound 3: 1.3-fold (0.10 log units) above; the range from low to high includes it.
By their numbers in this assay, from the lowest: compound 2; then compound 1; then compound 3.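

Among the compounds shown here, replacing phenoxy with hydrogen on this aromatic carbon is the first change in a single place that can be read here, and it gives a 2.7-fold higher number from compound 1 to compound 3 (0.44 log units; beyond the scatter) in this assay for a loss of seven heavy atoms. The phenoxy group therefore adds to the strength of inhibition but does not account for all of it, as compound 3 without it still gives 120 nM in the same measurement. No measurement shown explains why the number rises at this position.

The compounds shown leave open whether a methoxy group, a fluorine atom or an amine on this carbon would keep the lower number of compound 1, or whether a whole phenoxy group is needed. They also leave open whether this change would have a similar effect on compound 2, with its large ring.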